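Carboxymethyl in place of thiazolylsulfanylethyl on the ring nitrogen

This account rests on a few compounds, and the source may have more. Where it says the series, first, only, none or still open, it means among the compounds named here.

Measured compounds:
compound 1, `O=C(c1cccs1)n1nc(-c2cccnc2)c2ccccc2c1=O`, 37%
compound 2, `O=c1c2ccccc2c(-c2cccnc2)nn1CCSc1nccs1`, 97%

In an assay on isolated protein (Oryctolagus cuniculus) with Thromboxane-A synthase (Homo sapiens) as the target, tested at 1 uM (a higher number here means more inhibition at the concentration tested (going by the name of the read-out), a lower number less inhibition), compound 2 stands highest of the two numbers measured; its nearest neighbour is compound 1, which sits lower by the step of a number 60 percentage points higher from compound 1 to compound 2 (beyond the scatter). Among the compounds with values here, that step, the exchange of the group on the aromatic nitrogen, was large and beyond the scatter, and it is the only measured step available. It shows that the group on the aromatic nitrogen moves the read-out strongly, but it does not tell in which direction a further exchange at the same place will go.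

Compound 3, `O=C(O)Cn1nc(-c2cccnc2)c2ccccc2c1=O`, differs from compound 2 by carboxy in place of ((1,3-thiazol-2-yl)sulfanyl)methyl on a saturated chain carbon bound to an aromatic nitrogen. Within the data shown here, since compound 2 holds the highest number seen and the single measured step says only that this position is sensitive, the change is expected to cost inhibition rather than add to it: a step of a number 47 percentage points lower from compound 2 to compound 3 (beyond the scatter) is estimated, beyond the scatter, with wide uncertainty. Compound 3 is therefore expected to give about 50%, in a range from 15% to 85%.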

Compound 3, a percentage reported as inhibition, at one concentration (the size of the read-out at that concentration, not a potency): 13%
The estimate for compound 3 lay 37 percentage points above the measured number; the measured number lies below the stated range.
By their numbers in this assay, from the lowest: compound 3; then compound 1; then compound 2.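

In this assay, within the data shown here, the step of a number 84 percentage points lower from compound 2 to compound 3 (beyond the scatter) shows that this place can lose inhibition as sharply as it can gain it, which the single upward step among the earlier compounds did not show. Carboxymethyl also falls short of (thiophen-2-yl)carbonyl, with a number 24 percentage points lower from compound 1 to compound 3 (beyond the scatter) as the step, so compound 3 holds the lowest number of the three and the groups on the aromatic nitrogen now rank in the order carboxymethyl, (thiophen-2-yl)carbonyl, 2-((1,3-thiazol-2-yl)sulfanyl)ethyl. The exchange removes the 1,3-thiazol-2-yl ring and the sulfur and brings in the carboxy group all at once, and no independent information accounts for the drop.

Going by these compounds, these compounds do not separate the loss of the ring and sulfur from the arrival of the carboxy group, so it stays open which of these changes carries the fall. On these data alone, a longer chain ending in a carboxylic acid, the methyl ester of the carboxymethyl group, or an amine at the end of the ethyl chain would each test part of this, and how any of them would read here remains unknown.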